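Sulfonyl aryl swap from compound 2 to compound 3

The source may hold more compounds than are shown below. What is called first, only, known or untested is meant among the compounds shown, and "the series" means these compounds.

Compound 2 `O=C(c1ccc(-c2cccc(NS(=O)(=O)c3cccc(Cl)c3)c2)s1)c1cc(F)c(F)c(O)c1F` gives 28% in an assay on HEK293 cells for inhibition of 17-beta-hydroxysteroid dehydrogenase type 1 (Mus musculus), read by HPLC, tested at 500 nM, in the presence of a further agent that is not named here; a higher number here means more inhibition at the concentration tested (going by the name of the read-out), a lower number less inhibition. Compound 1 `O=C(c1ccc(-c2cccc(NS(=O)(=O)c3ccc(F)cc3)c2)s1)c1cc(F)c(F)c(O)c1F` gives 24% in this assay; the two numbers lie within the scatter of each other, so neither can be set above the other. Compound 3 `O=C(c1ccc(-c2cccc(NS(=O)(=O)c3ccc(Cl)cc3)c2)s1)c1cc(F)c(F)c(O)c1F` differs from compound 2 by 4-chlorophenyl in place of 3-chlorophenyl on a sulfonyl sulfur. For the measured compounds named here, the one measured step, a number 4 percentage points higher from compound 1 to compound 2 (within the scatter), also changed the aryl group on the sulfonyl sulfur and stayed within the scatter; it bears on this change only loosely. The step of a number 2 percentage points lower from compound 2 to compound 3 (within the scatter) is therefore expected to stay within the scatter. Compound 3 is estimated at 26%, ranging from 12% to 40%.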

Compound 3, a percentage reported as inhibition, at one concentration (the size of the read-out at that concentration, not a potency): 31%
For compound 3 the middle estimate is 5 percentage points below the measured one; measured number inside the range.
By their numbers in this assay, from the lowest: compounds 1, 2 and 3 (each within the scatter of the next).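

In this assay, 4-chlorophenyl in place of 3-chlorophenyl on a sulfonyl sulfur gives a number 3 percentage points higher from compound 2 to compound 3 (within the scatter) and chloro in place of fluoro on an aromatic carbon gives a number 7 percentage points higher from compound 1 to compound 3 (within the scatter). On this sulfonyl sulfur, neither the place of the chlorine on the phenyl ring nor the choice between chloro and fluoro gives a readable difference among these three compounds. No measurement on hand explains the closeness of these numbers. Open, as far as these compounds go, is whether a group of another kind on the sulfonyl sulfur, such as a methyl, an aminophenyl or a carboxyphenyl, would move the number beyond the scatter.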